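Shortening the Alkoxy Chain and Inserting an Ether Oxygen

The compounds below may be only part of what the source reports. "The series", "measured", "known", "first", "only" and "open" are said of these compounds alone.

Compound 3 `CCCCCCCCCCCCOc1ccc(C(=O)Nc2c(C)cc(C)c3c2OC(C)(C)C3)cc1` gives 90 nM in an assay for inhibition of acyl-CoA:cholesterol acyltransferase (Oryctolagus cuniculus), using microsomes; on this read-out higher numbers stand for weaker inhibition and lower numbers for stronger inhibition. Among the three compounds measured so far it holds the second highest number: compound 2 `CCCCCCCCCCOc1ccc(C(=O)Nc2c(C)cc(C)c3c2OC(C)(C)C3)cc1` gives 30 nM in this assay, and compound 1 `CCCCCCCCCCC1(C(=O)Nc2c(C)ccc3c2OC(C)(C)C3)CCCC1`, which carries a different core, gives 240 nM. For the measured compounds named here, the single measured step that bears on the chain is a 3.0-fold higher number from compound 2 to compound 3 (0.48 log units; beyond the scatter), where the chain grew longer at its far end and the number rose. Compound 4 `CCCOCCCCCCOc1ccc(C(=O)Nc2c(C)cc(C)c3c2OC(C)(C)C3)cc1` differs from compound 3 by propoxy in place of hexyl on a saturated chain carbon, six bonds along the chain from an oxygen on an aromatic ring. Here the chain grows shorter rather than longer, which the step from compound 2 to compound 3 would suggest should lower the number, but no measured pair shows what an ether oxygen within the chain does, so that part of the change is untested. A modest step downward, close to the scatter, is therefore expected, a 1.5-fold lower number from compound 3 to compound 4 (0.18 log units; within the scatter). Compound 4 is estimated to give 60 nM in this assay, within a range from 25 nM to 150 nM.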

Compound 4, half-maximal inhibitory concentration: > 200 nM
Compound 4: no number, only a limit (the forecaster's own chance of this, stated with the estimate: 2%); at least 3.3-fold (0.52 log units) between middle value and limit.
By their numbers in this assay, from the lowest: compound 2; then compound 3; then compound 1.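

In this assay compound 4 carries a limit and not a number: the limit of > 200 nM in this assay, at which 1 of the 4 values shown sits. Propoxy in place of hexyl gives an at least 2.2-fold higher number from compound 3 to compound 4 (0.34 log units; beyond the scatter), and propoxy in place of butyl gives an at least 6.6-fold higher number from compound 2 to compound 4 (0.82 log units; beyond the scatter). For the compounds shown here, until now the only measured rise at the far end of the alkoxy chain came with a longer chain, whereas here the number rises with propoxy, so chain growth is not the only change in this chain that raises the number, and the step from compound 2 is the larger of the two.

The compounds shown leave open how far past its limit compound 4 lies, and so the true size of both steps. They also leave open whether a decyl-length chain carrying an amine or a sulfur atom in place of the ether oxygen would behave like compound 2 or like compound 4.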